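A few compounds are considered here, and "the series" means these few. Any claim that something is new, unique, unknown or untested is made for them only; others in the source may bear on it.

Of the compounds shown here, three have been measured in a functional assay on SR cells (Homo sapiens) for inhibition, read by sulforhodamine B assay, with a stated time of 48 h; on this read-out lower numbers stand for stronger inhibition of growth and higher numbers for weaker inhibition of growth. Compound 1 `O=C(Nc1cccc(-n2cc(-c3ccncc3)c(-c3ccc(Cl)c(O)c3)n2)c1)Nc1cccc(C(F)(F)F)c1` gives 20000 nM, compound 3 `O=C(Nc1cccc(-n2cc(-c3ccncc3)c(-c3ccc(Cl)c(O)c3)n2)c1)Nc1ccc(Cl)c(Cl)c1` gives 15000 nM, and compound 2 `COc1cc(-c2nn(-c3cccc(NC(=O)c4cccc(C(F)(F)F)c4)c3)cc2-c2ccncc2)ccc1Cl` gives 4590 nM. Compound 2 therefore shows the lowest number of the three; its gap to compound 3 and its gap to compound 1 both lie beyond the scatter, so compound 2 is the strongest growth inhibitor measured so far.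

Compound 4 `COc1cc(-c2nn(-c3cccc(NC(=O)c4ccc(Cl)c(C(F)(F)F)c4)c3)cc2-c2ccncc2)ccc1Cl` is derived from compound 2 by a single change: chloro in place of hydrogen on an aromatic carbon. Within the data shown here, only one measured step touches a similar region of the molecule, namely a 1.3-fold lower number from compound 1 to compound 3 (0.12 log units; within the scatter), where the amide-type nitrogen carries a different halogen-substituted phenyl ring; that step stayed within the scatter. Compounds 1 and 3 differ from compounds 2 and 4 in their core, so this step is only a loose guide, but it gives no sign that an added chloro on this ring shifts growth inhibition much.

The change from compound 2 to compound 4 is therefore expected to be a 1.1-fold lower number from compound 2 to compound 4 (0.06 log units; within the scatter), with no shift beyond the scatter. Compound 4 is estimated to give 4000 nM in this assay, between 1500 nM and 11000 nM.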

Compound 4, concentration for total growth inhibition: > 32500 nM
Compound 4 gave a limit, no number; the forecaster's own chance of this, stated with the estimate: 5%; at least 8.1-fold (0.90 log units) between middle value and limit.
By their numbers in this assay, from the lowest: compound 2; then compounds 3 and 1 (each within the scatter of the next). At a limit, above all of these: compound 4.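

In this assay, one chloro added to the 3-(trifluoromethyl)phenyl ring, ortho to the trifluoromethyl group and para to a large group, gives an at least 7.0-fold higher number from compound 2 to compound 4 (0.85 log units; beyond the scatter). Compound 4 reads as a limit and not a number: the limit of > 32500 nM in this assay, at which 1 of the 4 values shown sits. Among these compounds, this position on compound 2 is therefore sensitive to the change, even though the only earlier step on a comparable ring, a 1.3-fold lower number from compound 1 to compound 3 (0.12 log units; within the scatter), stayed within the scatter and involved a different core and a different substitution.

From the compounds shown here alone, the true size of the loss stays open, and so does whether the same chloro would have a similar effect on the core of compound 1. It is also unclear whether the loss is specific to chloro, and a methyl group, an amine or a carboxylic acid at this same position would help to answer that.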